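The compounds below may be only part of what the source reports. "The series", "measured", "known", "first", "only" and "open" are said of these compounds alone.

Measured compounds:
- compound 1, `CC(C)(N)C(=O)N[C@H](COCc1ccccc1)c1nnnn1Cc1ccc(NS(C)(=O)=O)cc1`: in an assay on isolated protein for displacement of a labelled ligand from growth hormone secretagogue receptor type 1 (Homo sapiens), with a stated time of 1 h (a higher number here means a weaker inhibitor, a lower number a stronger inhibitor), compound 1 gives only a limit of the assay, > 5000 nM.
- compound 2, `CC(C)(N)C(=O)N[C@H](COCc1ccccc1)c1nnnn1CCCc1ccccc1`: compound 2 gives 200 nM.
- compound 3, `CCCCNC(=O)CCn1nnnc1[C@@H](COCc1ccccc1)NC(=O)C(C)(C)N`: compound 3 gives 2190 nM.

Among the two plain numbers, compound 3 has the higher one, so it is the weaker binder of that pair; the step of an 11-fold higher number from compound 2 to compound 3 (1.04 log units; beyond the scatter) is large and well beyond the scatter. Compound 1 sits at the limit (the limit of > 5000 nM in this assay, at which 1 of the 3 values shown sits), and the step of an at least 2.2-fold lower number from compound 1 to compound 3 (0.35 log units; beyond the scatter) is at least modest.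

Compound 4, `CC(C)(N)C(=O)N[C@H](COCc1ccccc1)c1nnnn1CCC(=O)NCc1ccccc1`, has not yet been measured. It differs from compound 3 by phenyl in place of propyl on a saturated chain carbon bound to an amide-type nitrogen: the butylcarbamoyl chain becomes a benzylcarbamoyl chain.

Among the compounds with values here, two measured steps bear on this. The step of an 11-fold higher number from compound 2 to compound 3 (1.04 log units; beyond the scatter) shows that the chain carrying a phenyl ring (in compound 2) gives a much lower number than the butylcarbamoyl chain of compound 3. Compound 4 keeps the amide of compound 3 but ends its chain in a phenyl ring, so a lowering toward compound 2 seems plausible, though the amide remains and compound 1 shows that an aryl group placed differently does not help. A modest step, a 2.2-fold lower number from compound 3 to compound 4 (0.34 log units; beyond the scatter), is therefore expected, and compound 4 is estimated at 1000 nM, within 300 nM to 4000 nM.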

Compound 4, inhibition constant: 1070 nM
Compound 4: middle estimate off by 1.1-fold (0.03 log units), on the low side; low and high end bracket the measured number.
By their numbers in this assay, from the lowest: compound 2; then compound 4; then compound 3. At a limit, above all of these: compound 1.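

In this assay, within the data shown here, phenyl in place of propyl on the saturated chain carbon bound to the amide-type nitrogen gives a 2.0-fold lower number from compound 3 to compound 4 (0.31 log units; beyond the scatter), so the amide-bearing chain tolerates a phenyl ring at its end and the number falls, something the earlier compounds, none of which joined a phenyl ring to this amide, could not show. The ring does not make up the whole gap to the amide-free chain, though: benzylcarbamoyl in place of benzyl gives a 5.4-fold higher number from compound 2 to compound 4 (0.73 log units; beyond the scatter), so with a phenyl ring at the end of both chains, the chain with the amide still gives the higher number. The step of an at least 4.6-fold lower number from compound 1 to compound 4 (0.66 log units; beyond the scatter) gives only a bound on the size of the change, and the limit behind it belongs to compound 1: the limit of > 5000 nM in this assay, at which 1 of the 4 values shown sits.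

The change adds a ring and more carbon atoms at once, so a cyclohexyl group in the same place would be needed to tell whether the aromatic ring itself matters or simply the larger group. Also open, on these data alone, is how a longer chain between the amide nitrogen and the phenyl ring, or a pyridine ring in place of phenyl, would move the number.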